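Swapping Bromo for Ethyl in a Weakly Active Pair

The compounds below may be only part of what the source reports. "The series", "measured", "known", "first", "only" and "open" are said of these compounds alone.

compound 1, `Nc1ccccc1NC(=O)c1ccc(COc2ccc(Br)cc2)cc1`: > 32000 nM
compound 2, `Nc1ccccc1NC(=O)c1ccc(COc2ccc(Cl)cc2)cc1`: 17300 nM

Both compounds were tested in a functional assay on HCT-116 cells (Homo sapiens) for antiproliferative activity, read by CCK-8 assay, with a stated time of 72 h; on this read-out lower numbers stand for stronger inhibition and higher numbers for weaker inhibition. For compound 1 this assay reports only a limit, > 32000 nM (the limit of > 32000 nM in this assay, at which 1 of the 2 values shown sits), so its true number is not known. Compound 2 gives 17300 nM. Among the measured compounds shown here, the single measured step, an at least 1.8-fold lower number from compound 1 to compound 2 (0.26 log units; that floor lies within the scatter), is the only guide available here, and it stays inside the usual scatter.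

Compound 3, `CCc1ccc(OCc2ccc(C(=O)Nc3ccccc3N)cc2)cc1`, has not been measured. It differs from compound 1 by ethyl in place of bromo on an aromatic carbon. Given that an at least 1.8-fold lower number from compound 1 to compound 2 (0.26 log units; that floor lies within the scatter) was barely visible when one halogen replaced another at that carbon, compound 3 is expected to sit close to where compound 1 stands, quite possibly again at the limit. The expected step is an at least 1.1-fold lower number from compound 1 to compound 3 (0.05 log units; that floor lies within the scatter). Compound 3 is therefore estimated at 28000 nM, in a range from 9000 nM to 80000 nM.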

Compound 3, half-maximal inhibitory concentration: 4830 nM
Compound 3: middle estimate off by 5.8-fold (0.76 log units), on the high side; measured number below the stated range.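

This position on the aromatic ring, para to a large group, turns out to respond to the group placed there, which the swap between two halogens could not show. In this assay, ethyl in place of chloro gives a 3.6-fold lower number from compound 2 to compound 3 (0.55 log units; beyond the scatter), so a change at this carbon can move the number clearly, and compound 3 is the lowest of the three compounds. Ethyl in place of bromo points the same way, with an at least 6.6-fold lower number from compound 1 to compound 3 (0.82 log units; beyond the scatter), but that step is only a floor, since compound 1 has a limit and not a number: the limit of > 32000 nM in this assay, at which 1 of the 3 values shown sits.

From the compounds shown here alone, whether a longer chain such as propyl, or an amine, at this same carbon would lower the number further remains open. The values shown also give no reason why ethyl stands apart from the two halogens.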